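This account rests on a few compounds, and the source may have more. Where it says the series, first, only, none or still open, it means among the compounds named here.

Measured in a functional assay on LoVo cells (Homo sapiens) for inhibition, read by MTT assay, with a stated time of 24 h; a higher number here means a weaker inhibitor, a lower number a stronger inhibitor:
- compound 1 `CC1(C)[C@H]2CC[C@]1(C)N(Cc1cn(-c3ccc(C#N)cc3)nn1)C(=O)C2`: 90 nM
- compound 2 `CC1(C)[C@H]2CC[C@]1(C)N(Cc1cn(-c3ccc(Br)cc3)nn1)C(=O)C2`: 60 nM

Among the measured compounds shown here, compound 2 stands level with compound 1, the only other measured compound: a 1.5-fold lower number from compound 1 to compound 2 (0.18 log units; within the scatter). Compound 3 `CC1(C)[C@H]2CC[C@]1(C)N(Cc1cn(-c3ccccc3O)nn1)C(=O)C2` has 2-hydroxyphenyl in place of 4-bromophenyl on an aromatic nitrogen. For the measured compounds named here, the one measured step, bromo in place of cyano on an aromatic carbon, stayed small, but it is a different change and only loosely bears on this one. Going by the values given here, no measured compound carries 2-hydroxyphenyl, so a wide range is kept. In this assay a moderate move to a higher number is expected, a 2.3-fold higher number from compound 2 to compound 3 (0.37 log units; beyond the scatter). For compound 3 the estimated value is 140 nM, with an expected range from 40 nM to 500 nM.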

Compound 3, half-maximal inhibitory concentration: 540 nM
Beside the measured number, compound 3's estimate is 3.9-fold (0.59 log units) below it; the measured number lies above the stated range.
By their numbers in this assay, from the lowest: compounds 2 and 1 (each within the scatter of the next); then compound 3.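

In this assay this position on the aromatic nitrogen proves sensitive to the aryl group: 2-hydroxyphenyl in place of 4-bromophenyl gives a 9.0-fold higher number from compound 2 to compound 3 (0.95 log units; beyond the scatter) and 2-hydroxyphenyl in place of 4-cyanophenyl gives a 6.0-fold higher number from compound 1 to compound 3 (0.78 log units; beyond the scatter) in this short series. The earlier bromo-for-cyano step, within the scatter, did not show this sensitivity. No measured evidence bears on what lies behind the weaker inhibition of compound 3.

Still open, on these data alone, is whether the hydroxy group itself or the absence of bromo and cyano accounts for the step. As far as these compounds go, how a methoxy group or an amine on the phenyl ring would read here also remains unknown.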